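A few compounds are considered here, and "the series" means these few. Any claim that something is new, unique, unknown or untested is made for them only; others in the source may bear on it.

Measured compounds:
- Compound 1, `CN1CCCc2cccc(NC(=O)c3ccc(-c4ccccc4)cc3)c21`, gives only a limit in a functional assay for antagonist activity at transient receptor potential cation channel subfamily V member 1 (Homo sapiens), read by FLIPR and calcium flux; a lower number here means a less potent compound, a higher number a more potent compound, by a factor of ten per unit of this negative logarithm: < 6.3.
- Compound 2, `O=C(Nc1ccc2c(c1)NCCC2)c1ccc(-c2ccccc2)cc1`, gives 7.7.
- Compound 3, `CN(C)CCN1CCCc2ccc(NC(=O)c3ccc(-c4ccccc4)cc3)cc21`, gives 7.4.

The three compounds share a biphenyl amide attached to a bicyclic core. Compound 1 sits at a limit of the assay, (the limit of < 6.3 in this assay, at which 1 of the 3 values shown sits), so it gives no number to compare. Within the data shown here, compound 3 stands at the lower of the two numbers; its nearest neighbour is compound 2, and the step of a number 0.30 log units lower from compound 2 to compound 3 (within the scatter) is the only measured change at this position, so the ring nitrogen tolerates a sizeable substituent without a clear loss.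

Compound 4, `COCC(=O)N1CCCc2ccc(NC(=O)c3ccc(-c4ccccc4)cc3)cc21`, is reached from compound 3 through ((methoxymethyl)carbonyl in place of 2-(dimethylamino)ethyl on a nitrogen on an aromatic ring in a ring). Among the measured compounds shown here, no measured step describes such an exchange, so the one step that bears on it is the tolerated swap from compound 2 to compound 3. The expected change a number 0.30 log units lower from compound 3 to compound 4 (within the scatter) is therefore small, and compound 4 is estimated at 7.1, within 6.3 to 7.9.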

Compound 4, negative logarithm of the antagonist equilibrium constant: 7.2
Estimate against measurement, compound 4: 0.10 log units below, within the range that was stated.
By their numbers in this assay, from the lowest: compounds 4, 3 and 2 (each within the scatter of the next, the first and the last beyond it). At a limit, below all of these: compound 1.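

In this assay, the nitrogen of the six-membered ring now carries a group joined through a carbonyl, and swapping the basic-free count of atoms is not the issue: both groups have 5 heavy atoms, and the exchange gives a number 0.20 log units lower from compound 3 to compound 4 (within the scatter). Set against the hydrogen on that nitrogen, the same group gives a number 0.50 log units lower from compound 2 to compound 4 (beyond the scatter), the first step at this position that passes the scatter, though it is modest in size. Nothing measured here gives a reason for that step.

Still open, from the compounds shown here alone, is how a simple acetyl group, or a longer chain ending in a carboxylic acid, would fare on this nitrogen. With (methoxymethyl)carbonyl the only carbonyl-linked group shown, the compounds also cannot separate any contribution of its carbonyl from that of its ether oxygen.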